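The compounds below may be only part of what the source reports. "The series", "measured", "known", "first", "only" and "open" are said of these compounds alone.

Measured compounds:
Compound 1 `O=C(Nc1cccc(-c2oc3cc(-c4ccc(F)cc4)ccc3c(=O)c2O)c1)c1ccc(F)cc1`: in a functional assay on HepG2 cells (Homo sapiens) for antiproliferative activity, read by CCK-8 assay, with a stated time of 72 h (a lower number here means a stronger inhibitor, a higher number a weaker inhibitor), compound 1 gives 9280 nM.
Compound 2 `O=C(Nc1cccc(-c2oc3cc(-c4ccc(F)cc4)ccc3c(=O)c2O)c1)c1cccc(F)c1`: in this assay compound 2 gives 15500 nM.
Compound 3 `O=C(Nc1cccc(-c2oc3cc(-c4ccc(F)cc4)ccc3c(=O)c2O)c1)c1ccc(Br)cc1F`: in this assay compound 3 reaches only a limit, > 100000 nM, and no number.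

Compound 3 therefore stands apart from the other two: its value is the limit of > 100000 nM in this assay, at which 1 of the 3 values shown sits, so only its floor of weakness is known. Compound 1 and compound 2 sit within the scatter of each other, the step being a 1.7-fold higher number from compound 1 to compound 2 (0.22 log units; within the scatter). The two steps into compound 3 are the ones that matter here: an at least 10-fold higher number from compound 1 to compound 3 (1.03 log units; beyond the scatter) and an at least 6.4-fold higher number from compound 2 to compound 3 (0.80 log units; beyond the scatter), both beyond the scatter and both in the direction of weaker inhibition.

Compound 4 `O=C(Nc1cccc(-c2oc3cc(-c4ccc(F)cc4)ccc3c(=O)c2O)c1)c1ccc(-c2ccccc2)cc1` is the next one to be measured. The change from compound 3 is 4-phenylphenyl in place of 4-bromo-2-fluorophenyl on a carbonyl carbon. The measured steps bear on it only in reverse: both steps that brought in 4-bromo-2-fluorophenyl raised the number, so removing it should bring the number back down in this assay, though 4-phenylphenyl is not among the groups measured so far, and how far it returns toward compound 1 or compound 2 is open. The expected step is an at least 3.3-fold lower number from compound 3 to compound 4 (0.52 log units; beyond the scatter). Compound 4 is estimated at 30000 nM, with a range from 8000 nM to 150000 nM.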

Compound 4, half-maximal inhibitory concentration: 88500 nM
The estimate for compound 4 lay 3.0-fold (0.47 log units) below the measured number; the measured number falls inside the stated range.
By their numbers in this assay, from the lowest: compounds 1 and 2 (each within the scatter of the next); then compound 4. At a limit, above all of these: compound 3.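

In this assay, phenyl in place of fluoro on an aromatic carbon gives a 9.5-fold higher number from compound 1 to compound 4 (0.98 log units; beyond the scatter), and 4-phenylphenyl in place of 3-fluorophenyl on the carbonyl carbon gives a 5.7-fold higher number from compound 2 to compound 4 (0.76 log units; beyond the scatter); a weaker result at this place therefore also appears with a group carrying no halogen, and compound 3 is no longer the only case. The comparison with compound 3 reads only as an at least 1.1-fold lower number from compound 3 to compound 4 (0.05 log units; that floor lies within the scatter), a floor within the scatter, and gives no order between 4-phenylphenyl and 4-bromo-2-fluorophenyl. Compound 3 remains at a limit, which is not a number: the limit of > 100000 nM in this assay, at which 1 of the 4 values shown sits.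

Still open, going by these compounds, is whether a small fluorophenyl is what this position needs in this assay, or whether an amine, a carboxylic acid or a methoxy group on the same phenyl ring, or a cyclohexyl ring on the carbonyl carbon, would hold the number near that of compound 1. The compounds shown also keep the rest of the core fixed and cover a single cell line, so they say nothing about how these steps would carry over to another core or other cells.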